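A few compounds are considered here, and "the series" means these few. Any claim that something is new, unique, unknown or untested is made for them only; others in the source may bear on it.

Of the compounds shown here, two have been measured so far in a functional assay on HeLa cells (Homo sapiens) for antiproliferative activity, read by MTT assay, with a stated time of 48 h (on this read-out lower numbers stand for stronger inhibition and higher numbers for weaker inhibition), and their values are these.

Compound 1 `C#Cc1cccc(Nc2ncnc3cc(NC(=O)/C=C/c4ccccc4)sc23)c1` gives 20500 nM
Compound 2 `O=C(/C=C/c1ccccc1)Nc1cc2ncnc(Nc3ccc(F)c(Cl)c3)c2s1` gives 2810 nM

Compound 2 holds the lower of the two numbers, and its gap to compound 1 lies beyond the scatter. Compound 3 `O=C(/C=C/c1ccccc1)Nc1cc2ncnc(Nc3ccc(Cl)c(Cl)c3)c2s1` has yet to be measured in this assay and differs from compound 2 in one place: chloro in place of fluoro on an aromatic carbon (chloro in place of fluoro on an aromatic carbon, turning 3-chloro-4-fluorophenyl into 3,4-dichlorophenyl). Among the measured compounds shown here, one measured step bears on this change, namely a 7.3-fold lower number from compound 1 to compound 2 (0.86 log units; beyond the scatter) and it was modest. For the measured compounds named here, that step exchanged 3-ethynylphenyl for 3-chloro-4-fluorophenyl, so it shows that this group can move the number, but no measured pair tests the exchange of one halogen alone. With compound 2 at 2810 nM as the starting point, a small step in either direction is expected, most likely none beyond the scatter. The expected shift is a 1.1-fold lower number from compound 2 to compound 3 (0.05 log units; within the scatter) and this estimate carries no firm direction. The estimated value for compound 3 is 2500 nM with 1000 nM and 6500 nM as the ends of its expected range.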

Compound 3, half-maximal inhibitory concentration: 10700 nM
The estimate for compound 3 lay 4.3-fold (0.63 log units) below the measured number, outside the stated range (above it).
By their numbers in this assay, from the lowest: compound 2; then compounds 3 and 1 (each within the scatter of the next).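

In this assay, a single halogen at this position proves enough to move the number: chloro in place of fluoro on an aromatic carbon, ortho to a chloro group and para to a large group, gives a 3.8-fold higher number from compound 2 to compound 3 (0.58 log units; beyond the scatter), which lies beyond the scatter. The earlier step exchanged a whole group, whereas this one isolates the fluoro, and the advantage of 3-chloro-4-fluorophenyl over 3-ethynylphenyl does not carry over to 3,4-dichlorophenyl: that exchange gives a 1.9-fold lower number from compound 1 to compound 3 (0.28 log units; within the scatter), within the scatter, so those two compounds cannot be told apart. Nothing available explains why this one exchange shifts the number.

The compounds shown compare only fluoro and chloro at this place, so it remains open how a bromo, a methoxy or a plain hydrogen there would read in this assay. All three compounds also carry the same amide side chain ending in a phenyl group, which leaves open what an amine or a carboxylic acid on that phenyl group would do to these numbers.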